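A few compounds are considered here, and "the series" means these few. Any claim that something is new, unique, unknown or untested is made for them only; others in the source may bear on it.

In a functional assay on HeLa cells (Homo sapiens) for cytotoxicity, read by MTT assay, with a stated time of 48 h (a higher number here means a weaker inhibitor, a lower number a stronger inhibitor), three compounds have been measured so far: compound 1 `Cc1cccc(Cn2cc(COc3ccc4c(=O)ccoc4c3)nn2)c1`, compound 2 `O=c1ccoc2cc(OCc3cn(Cc4ccc(F)cc4)nn3)ccc12` and compound 3 `O=c1ccoc2cc(OCc3cn(Cc4cccc(Cl)c4)nn3)ccc12`. Compound 3 gives > 100000 nM, which is a limit of the assay and not a number. Compound 1 likewise gives only a limit, > 100000 nM. Compound 2 alone gives a number, 12000 nM. Compound 3 thus stands at the limit of > 100000 nM in this assay, at which 2 of the 3 values shown sit.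

Compound 4 `O=c1ccoc2cc(OCc3cn(Cc4ccc(Br)cc4)nn3)ccc12` differs from compound 3 as follows: 4-bromophenyl in place of 3-chlorophenyl on a saturated chain carbon bound to an aromatic nitrogen. In words, 4-bromophenyl stands in place of 3-chlorophenyl on a saturated chain carbon bound to an aromatic nitrogen.

Among the compounds with values here, two measured steps bear most directly on this change. One is an at least 8.3-fold higher number from compound 2 to compound 3 (0.92 log units; beyond the scatter), and the other is an at least 8.3-fold lower number from compound 1 to compound 2 (0.92 log units; beyond the scatter). Within the data shown here, both lie beyond the scatter, and both mark the 4-fluorophenyl group of compound 2 as the one that yields a number. The third step, a step that the two limits leave unreadable from compound 1 to compound 3, cannot be read. Among the measured compounds shown here, no measured compound yet carries bromine, so the comparison with compound 2 rests on a single pair of groups.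

Compound 4 is therefore expected to fall closer to compound 2 than to the limit. The estimated step is an at least 5.0-fold lower number from compound 3 to compound 4 (0.69 log units; beyond the scatter), a lower number and at least modest in size. For compound 4 the expected value is 20000 nM, with an estimated range from 5000 nM to 80000 nM.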

Compound 4, half-maximal inhibitory concentration: > 100000 nM
Compound 4: only a limit was reported; the forecaster's own chance of this, stated with the estimate: 30%; at least 5.0-fold (0.69 log units) between middle value and limit.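

In this assay compound 4 gives > 100000 nM, which is a limit of the assay and not a number. Within the data shown here, the earlier pair of halogen compounds differed in both the halogen and the group's name, 4-fluorophenyl against 3-chlorophenyl, whereas here bromo in place of fluoro on an aromatic carbon is the only change, and it gives an at least 8.3-fold higher number from compound 2 to compound 4 (0.92 log units; beyond the scatter), so keeping a 4-substituted phenyl with a halogen is not enough to retain a measurable value. The steps that join two limits cannot be read, and compound 2 remains the only compound shown with a number: the limit of > 100000 nM in this assay, at which 3 of the 4 values shown sit.

On these data alone, how far compounds 1, 3 and 4 lie past the limit stays open, so no order can be given among them. Also open, as far as these compounds go, is whether the value of compound 2 is particular to fluoro or would extend to 4-chlorophenyl, or to a phenyl carrying an amine or a carboxylic acid, at the same saturated chain carbon bound to an aromatic nitrogen.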